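This account rests on a few compounds, and the source may have more. Where it says the series, first, only, none or still open, it means among the compounds named here.

Measured in an ADME assay on MT4 cells (Homo sapiens) for cytotoxicity; on this read-out higher numbers stand for lower toxicity in this test and lower numbers for higher toxicity in this test:
- Compound 1 `COc1cccc(NC(=S)Nc2cccc(C(F)(F)F)c2)c1`: 26000 nM
- Compound 2 `FC(F)(F)c1cccc(NC(=S)Nc2ccccc2)c1`: 39000 nM
- Compound 3 `CC(=O)NC(=S)Nc1cccc(C(F)(F)F)c1`: > 100000 nM, a limit of the assay

On the numbers shown, compound 3 has no exact value, only a limit: > 100000 nM. Compound 4 `FC(F)(F)c1cccc(NC(=S)Nc2cccc(Br)c2)c1` differs from compound 3 at one place: 3-bromophenyl in place of acetyl on an amide-type nitrogen. In words, 3-bromophenyl stands in place of acetyl on an amide-type nitrogen.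

Among the compounds with values here, two measured steps bear on this change. The closer one is an at least 2.5-fold higher number from compound 2 to compound 3 (0.40 log units; beyond the scatter). It exchanges phenyl for acetyl at that same kind of nitrogen, and read backwards it points to a lower number for compound 4, by a size left open at one end. The other is a 1.5-fold higher number from compound 1 to compound 2 (0.18 log units; within the scatter), where hydrogen in place of methoxy on an aromatic carbon stays within the scatter. On that evidence the bromine is expected to add only a little to what the aromatic ring itself brings.

In this assay, a fall beyond the scatter is therefore expected, to about the level of compound 1 and compound 2. The expected change is an at least 4.0-fold lower number from compound 3 to compound 4 (0.60 log units; beyond the scatter). Compound 4 is estimated at 25000 nM, with an expected range from 10000 nM to 60000 nM.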

Compound 4, half-maximal cytotoxic concentration: 9200 nM
Estimate against measurement, compound 4: 2.7-fold (0.43 log units) above; the measured number lies below the stated range.
By their numbers in this assay, from the lowest: compound 4; then compounds 1 and 2 (each within the scatter of the next). At a limit, above all of these: compound 3.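

In this assay, a substituent on the aromatic ring proves able to move the number, which compounds 1, 2 and 3 alone did not show: bromo in place of hydrogen on an aromatic carbon gives a 4.2-fold lower number from compound 2 to compound 4 (0.63 log units; beyond the scatter), while methoxy and hydrogen differ only by a 1.5-fold higher number from compound 1 to compound 2 (0.18 log units; within the scatter). Bromo in place of methoxy likewise gives a 2.8-fold lower number from compound 1 to compound 4 (0.45 log units; beyond the scatter), so compound 4 has the lowest number of the four, beyond the scatter from each of the others, and stands for the highest toxicity in this test among them. On the amide-type nitrogen, 3-bromophenyl in place of acetyl gives an at least 10-fold lower number from compound 3 to compound 4 (1.03 log units; beyond the scatter), a step open at one end since compound 3 stands at a limit of the assay: the limit of > 100000 nM in this assay, at which 1 of the 4 values shown sits.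

From the compounds shown here alone, whether the fall belongs to bromine alone stays open, since chlorine, a nitrile or an amine in its stead on that ring would be needed to tell. Also open, going by these compounds, is whether a longer chain in place of acetyl on that nitrogen would keep the number at the limit, and how far the true number of compound 3 lies beyond it.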